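Adding an azidopropyl chain to the ring amine of compound 1

The source may hold more compounds than are shown below. What is called first, only, known or untested is meant among the compounds shown, and "the series" means these compounds.

Compound 1, `O=C(OCC1CCCNC1)c1ccccc1-c1ccccc1`, was examined in an in vitro functional assay on HEK ts201 cells for antagonist activity at Neuronal acetylcholine receptor; alpha4/beta2 (Homo sapiens), read by fluorescence and calcium flux; on this read-out lower numbers stand for stronger inhibition and higher numbers for weaker inhibition; compound 1 gave 7080 nM. Among the three compounds measured so far, compound 1 holds the second highest number. Its nearest neighbour is compound 3, `O=C(OCC1CCCN(C(=O)CCc2ccccc2)C1)c1ccccc1C(F)(F)F`, for which this assay gave 3900 nM, a gap that lies within the usual scatter. Furthest away is compound 2, `O=C(NCC1CCCN(CCCc2ccccc2)C1)c1ccccc1-c1ccccc1`, for which this assay gave 20000 nM, a gap that goes beyond the scatter. No pair among these three differs in only one place, so no single step can be read off them.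

Compound 4, `[N-]=[N+]=NCCCN1CCCC(COC(=O)c2ccccc2-c2ccccc2)C1`, differs from compound 1 in one place: 3-azidopropyl in place of hydrogen on an amine nitrogen in a ring. Nothing measured here isolates the effect of a chain on that nitrogen, and the two substituted compounds, compound 2 and compound 3, sit on opposite sides of compound 1. Compound 4 is therefore expected to land close to compound 1, with a step from compound 1 to compound 4 of a 1.4-fold higher number from compound 1 to compound 4 (0.15 log units; within the scatter), not clearly beyond the scatter. The estimate for compound 4 is 10000 nM, within a range from 3000 nM to 40000 nM.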

Compound 4, half-maximal inhibitory concentration: 4270 nM
For compound 4 the middle estimate is 2.3-fold (0.37 log units) above the measured one; measured number inside the range.
By their numbers in this assay, from the lowest: compounds 3, 4 and 1 (each within the scatter of the next); then compound 2.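

In this assay, the change gives a 1.7-fold lower number from compound 1 to compound 4 (0.22 log units; within the scatter), the first step among these compounds that can be read at a single place. For this one pair, replacing hydrogen with 3-azidopropyl on the amine nitrogen in the ring leaves the number within the scatter, so a free hydrogen on that nitrogen is not needed to keep a value of this order on the core of compound 1. No supporting data bear on why the two numbers stay so close.

As far as these compounds go, it remains open whether a plain propyl chain, a longer chain, or a chain ending in an amine or a carboxylic acid would also stay within the scatter of compound 1. A single pair also cannot show whether the same holds on the amide or trifluoromethyl-bearing cores.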